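The compounds below may be only part of what the source reports. "The series", "measured", "known", "first", "only" and "open" are said of these compounds alone.

In an ADME assay on CHO-K1 cells (Cricetulus griseus) for cytotoxicity, read by MTT assay, with a stated time of 24 h (on this read-out lower numbers stand for higher toxicity in this test and higher numbers for lower toxicity in this test), compound 1 `S=C(Nc1ccccc1)Nc1ccc2[nH]ccc2c1` gives 337000 nM. Compound 2 `Oc1ccccc1NC(=S)Nc1ccc2[nH]ccc2c1`, with hydroxy in place of hydrogen on an aromatic carbon, gives 509000 nM. Among the compounds with values here, these are the only two true numbers so far, and they lie within the scatter of each other. Compound 3 `S=C(Nc1ccc2[nH]ccc2c1)Nc1cccc2cnccc12` gives > 400000 nM, which is a limit of the assay and not a number.

Compound 4 `Cc1ccc(NC(=S)Nc2ccc3[nH]ccc3c2)c(O)c1` is compound 2 with methyl in place of hydrogen on an aromatic carbon, para to a large group and meta to a hydroxy group: methyl in place of hydrogen on an aromatic carbon. Within the data shown here, no step that introduces methyl has been measured. Among the measured compounds shown here, the only measured step, a 1.5-fold higher number from compound 1 to compound 2 (0.18 log units; within the scatter), also replaces hydrogen on an aromatic carbon, and it stays within the scatter. On that slim basis, no step beyond the scatter is expected in this assay. The expected change is a 1.1-fold lower number from compound 2 to compound 4 (0.05 log units; within the scatter). The estimated value for compound 4 is 450000 nM, with an expected range from 220000 nM to 800000 nM.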

Compound 4, concentration lethal to 50% of the cells: 370000 nM
For compound 4 the middle estimate is 1.2-fold (0.09 log units) above the measured one; the range from low to high includes it.
By their numbers in this assay, from the lowest: compounds 1, 4 and 2 (each within the scatter of the next).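

In this assay, within the data shown here, this is the first measured case of methyl on this carbon, para to a large group and meta to a hydroxy group, and it gives a 1.4-fold lower number from compound 2 to compound 4 (0.14 log units; within the scatter). Together with the earlier hydroxy change, a 1.5-fold higher number from compound 1 to compound 2 (0.18 log units; within the scatter), this means that both measured replacements of hydrogen on this six-membered aromatic ring stay within the scatter, so the test does not tell compound 2 and compound 4 apart. Compound 3 remains a limit and not a number, so it cannot be placed among them: the limit of > 400000 nM in this assay, at which 1 of the 4 values shown sits.

The compounds shown leave open whether an amine, a carboxylic acid or a longer chain at this same place would move the number beyond the scatter. They also leave open whether methyl would behave the same way on compound 1, which has no hydroxy group.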